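Hydroxyphenyl hydrazones: swapping a fluorine for an amine

A few compounds are considered here, and "the series" means these few. Any claim that something is new, unique, unknown or untested is made for them only; others in the source may bear on it.

Measured so far:
Compound 1, `C/C(=N\NC(=O)c1cccc(S(=O)(=O)N2CCOCC2)c1)c1cccc(O)c1`, in a functional assay on PC-3 cells (Homo sapiens) for antiproliferative activity, read by MTT assay, with a stated time of 72 h (a lower number here means a stronger inhibitor, a higher number a weaker inhibitor), gives a limit of > 100000 nM.
Compound 2, `C/C(=N\NC(=O)c1cccc(S(=O)(=O)N2CCOCC2)c1)c1cc(Br)ccc1O`, gives 6890 nM.
Compound 3, `C/C(=N\NC(=O)c1cccc(S(=O)(=O)N2CCOCC2)c1)c1cc(F)ccc1O`, gives 4410 nM.

Compound 3 has the lowest of the two numbers; its nearest neighbour is compound 2, and the step of a 1.6-fold lower number from compound 2 to compound 3 (0.19 log units; within the scatter) is within the scatter, so the two cannot be ranked. Compound 1 sits at the limit described by the limit of > 100000 nM in this assay, at which 1 of the 3 values shown sits. The two large steps, an at least 14-fold lower number from compound 1 to compound 2 (1.16 log units; beyond the scatter) and an at least 22-fold lower number from compound 1 to compound 3 (1.35 log units; beyond the scatter), show that moving the hydroxyl and adding a halogen matters a great deal, while the halogen swap itself did little.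

Compound 4, `C/C(=N\NC(=O)c1cccc(S(=O)(=O)N2CCOCC2)c1)c1cccc(N)c1O`, is the new compound. The change is 3-amino-2-hydroxyphenyl in place of 5-fluoro-2-hydroxyphenyl on a carbon with a double bond to nitrogen. The hydroxyl stays in the 2-position, which the large steps from compound 1 point to as the important feature. Among the compounds with values here, no measured step covers an amino group, and the halogen swap within the scatter gives no guide to this different substituent. A small step is therefore expected, in no firm direction, and compound 4 is estimated at 7000 nM, in the range 2500 nM to 25000 nM, corresponding to an expected step of a 1.6-fold higher number from compound 3 to compound 4 (0.20 log units; within the scatter).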

Compound 4, half-maximal inhibitory concentration: 2330 nM
Beside the measured number, compound 4's estimate is 3.0-fold (0.48 log units) above it, and the stated range ends above it.
By their numbers in this assay, from the lowest: compounds 4, 3 and 2 (each within the scatter of the next, the first and the last beyond it). At a limit, above all of these: compound 1.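

This position tolerates losing the halogen altogether: 3-amino-2-hydroxyphenyl holds up as well as 5-fluoro-2-hydroxyphenyl, since a 1.9-fold lower number from compound 3 to compound 4 (0.28 log units; within the scatter) leaves the two unranked. The amino compound also separates from the bromo one, with a 3.0-fold lower number from compound 2 to compound 4 (0.47 log units; beyond the scatter), although that step is only modest and the two halogen compounds themselves cannot be ranked. The step of an at least 42-fold lower number from compound 1 to compound 4 (1.63 log units; beyond the scatter) is the widest shown, but it gives a bound and not a true size, as its starting point is a limit: the limit of > 100000 nM in this assay, at which 1 of the 4 values shown sits.

Going by these compounds, the change from compound 3 swaps the group and also moves it, as the names 5-fluoro and 3-amino show, so it stays open whether the amino group or its new place accounts for the result, and 5-amino-2-hydroxyphenyl would separate the two. On these data alone, it is equally open whether the amino group is needed at all, which a plain 2-hydroxyphenyl with no further group, or a ring carrying a methoxy or dimethylamino group in its place, would help to settle.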